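Aromatic ester series: trifluoromethyl on the benzoate ring

The source may report more compounds than this note shows. Statements on the series, on what has been measured and on what is new or still open speak of the compounds shown alone.

Measured compounds:
- compound 1 `CC1=CC[C@H](C(C)C)c2cc(C)c(OC(=O)c3ccc(C)cc3)cc21` — 85.4%
- compound 2 `CC1=CC[C@H](C(C)C)c2cc(C)c(OC(=O)c3ccccc3)cc21` — 37%
- compound 3 `CC1=CC[C@H](C(C)C)c2cc(C)c(OC(=O)c3ccc(C(F)(F)F)cc3)cc21` — "not active" (no number reported)

In a functional assay on SK-LU-1 cells (Homo sapiens) for antiproliferative activity, read by sulforhodamine B assay, with a stated time of 48 h, tested at 50 uM (on this read-out lower numbers stand for less inhibition and higher numbers for more inhibition at the one concentration tested (going by the name of the read-out)), compound 2 gives the lowest of the two numbers; compound 1 stands higher, and the step of a number 48.4 percentage points lower from compound 1 to compound 2 (beyond the scatter) is large. Compound 3, bearing a trifluoromethyl group, is reported in this assay as "not active" (no number reported), without a number.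

Compound 4 `CC1=CC[C@H](C(C)C)c2cc(C)c(OC(=O)c3cccc(C(F)(F)F)c3)cc21` is not yet measured. It differs from compound 2 by trifluoromethyl in place of hydrogen on an aromatic carbon. Within the data shown here, no measured step bears on this change directly; compound 3 shows only that a trifluoromethyl group at another place on this ring gave no reportable activity. Compound 4 is therefore expected to move downward, by a number 17 percentage points lower from compound 2 to compound 4 (beyond the scatter), and may also fall to a report of no activity. The estimate for compound 4 in this assay is 20%, within 0% to 45%.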

Compound 4, a percentage reported as inhibition, at one concentration (the size of the read-out at that concentration, not a potency): 18.3%
Compound 4: middle estimate off by 1.7 percentage points, on the high side; the range from low to high includes it.
By their numbers in this assay, from the lowest: compound 4; then compound 2; then compound 1.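

In this assay, trifluoromethyl in place of hydrogen on the ring carbon meta to a large group gives a directly measured step for this change, a number 18.7 percentage points lower from compound 2 to compound 4 (beyond the scatter), and it is a lowering rather than a gain. Compound 4 keeps a reportable number, 18.3%, so a trifluoromethyl group on this ring need not end in a report of no activity. No measurement shown accounts for the drop. Still open, from the compounds shown here alone, is how a methyl, a chlorine or an amine at this same place would compare with trifluoromethyl and with hydrogen.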